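Ring amide nitrogen substituents and tolerated concentration

A few compounds are considered here, and "the series" means these few. Any claim that something is new, unique, unknown or untested is made for them only; others in the source may bear on it.

compound 1 `O=C1Nc2ccccc2/C1=N/NC(=S)Nc1ccccc1`: > 25000 nM, a limit in an ADME assay on RD cells (Homo sapiens) for cytotoxicity; a lower number here means that less compound is tolerated, a higher number that more compound is tolerated
compound 2 `CCN1C(=O)/C(=N\NC(=S)Nc2ccccc2)c2ccccc21`: > 25000 nM, a limit in this assay

Compound 2 stands only at a limit, as the limit of > 25000 nM in this assay, at which 2 of the 2 values shown sit, shows. The step that the two limits leave unreadable from compound 1 to compound 2 is therefore not readable. Compound 3 `O=C1/C(=N\NC(=S)Nc2ccccc2)c2ccccc2N1c1ccccc1` differs by phenyl in place of ethyl on an amide-type nitrogen in a ring. Among the compounds with values here, no measured step bears on this change, and no step size is readable. Compound 3 is expected to sit near the same limit, giving an estimated 30000 nM (range 8000 nM to 100000 nM). The expected step is a step that the limit leaves unreadable from compound 2 to compound 3, none beyond the scatter.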

Compound 3, half-maximal cytotoxic concentration: > 25000 nM
Compound 3: only a limit was reported (the forecaster's own chance of this, stated with the estimate: 70%); the middle value lies beyond the limit too.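

No new step can be read among compound 1, compound 2 and compound 3, since each is reported only as a limit: the limit of > 25000 nM in this assay, at which 3 of the 3 values shown sit.

As far as these compounds go, whether hydrogen, ethyl and phenyl on the ring amide nitrogen differ at all in this assay stays open.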